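This account rests on a few compounds, and the source may have more. Where it says the series, first, only, none or still open, it means among the compounds named here.

Of the compounds shown here, three sharing one core have been measured in an ADME assay on microsomes from liver (Homo sapiens) for metabolic stability; a higher number here means faster removal of the compound, a lower number slower removal. There compound 1 `CC(=O)N[C@@H]1CCC[C@H](C(=O)Nc2cc(-c3cnn(C)c3C)c(Cl)cn2)C1` gives 3.3 mL.min-1.g-1, and compound 2 `CC(=O)N[C@@H]1CCC[C@H](C(=O)Nc2cc(-c3cnc4n3CCCC4)c(Cl)cn2)C1` gives 16 mL.min-1.g-1. Compound 3 `CC(=O)N[C@@H]1CCC[C@H](C(=O)Nc2cc(-c3cnn4c3COCC4)c(Cl)cn2)C1` is reported only as a limit, < 3 mL.min-1.g-1. It therefore stands at the limit of < 3 mL.min-1.g-1 in this assay, at which 1 of the 3 values shown sits.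

Compound 4 `CC(=O)N[C@@H]1CCC[C@H](C(=O)Nc2cc(-c3cnn4c3CN(C)CC4)c(Cl)cn2)C1` differs from it in one place: a group of 10 heavy atoms (7 carbon, 3 nitrogen; one five-membered aromatic ring with 2 hetero atoms, one six-membered non-aromatic ring with 2 hetero atoms) in place of a group of 9 heavy atoms (6 carbon, 2 nitrogen, 1 oxygen; one five-membered aromatic ring with 2 hetero atoms, one six-membered non-aromatic ring with 2 hetero atoms), on an aromatic carbon. The oxygen-containing group leaves, and a group with one more nitrogen enters, on the same aromatic carbon.

The closest measured evidence is the step that brought in that oxygen-containing group, which gave an at least 5.3-fold lower number from compound 2 to compound 3 (0.72 log units; beyond the scatter). Against compound 1, the same group gave an at least 1.1-fold lower number from compound 1 to compound 3 (0.04 log units; that floor lies within the scatter), while the group of compound 2 gave a 4.8-fold higher number from compound 1 to compound 2 (0.69 log units; beyond the scatter). These steps show that this assay responds to changes at this place, but none of them tests the group entering in compound 4.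

A small rise is therefore expected, short of the value of compound 2, 16 mL.min-1.g-1. The expected change is an at least 2.0-fold higher number from compound 3 to compound 4 (0.30 log units; that floor lies within the scatter). For compound 4, the estimate in this assay is 6 mL.min-1.g-1, with an expected range of 3 mL.min-1.g-1 to 14 mL.min-1.g-1.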

Compound 4, intrinsic clearance in microsomes in the Homo sapiens assay: < 3 mL.min-1.g-1
Compound 4 gave a limit, no number; the forecaster's own chance of this, stated with the estimate: 25%; middle value at least 2.0-fold (0.30 log units) away from the limit.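

In the Homo sapiens assay, compound 4, like compound 3, is reported only as a limit: the limit of < 3 mL.min-1.g-1 in the Homo sapiens assay, at which 2 of the 4 values shown sit. Against the earlier groups, the entering group gives an at least 5.3-fold lower number from compound 2 to compound 4 (0.72 log units; beyond the scatter), and it also gives an at least 1.1-fold lower number from compound 1 to compound 4 (0.04 log units; that floor lies within the scatter), while the steps between compound 3 and compound 4 in this assay cannot be read, so an oxygen in the non-aromatic ring is not required for a number at this limit. The exchange of the oxygen-containing group for the group with one more nitrogen does show a readable difference in a physicochemical assay for solubility, in phosphate buffer, at pH 7.4; a higher number here means a more soluble compound, a lower number a less soluble compound: the measured solubility of compound 3, 220000 nM, and of compound 4, 870000 nM, a 4.0-fold higher number (0.60 log units; beyond the scatter). In the physicochemical assay compound 3 gives 220000 nM, and compound 4 gives 870000 nM.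

From the compounds shown here alone, how far compound 3 and compound 4 lie from this limit in the Homo sapiens assay stays open. Also open, going by these compounds, is whether a larger group on the ring nitrogen of compound 4, such as an ethyl group or a longer chain, would keep both read-outs where they stand.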